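The source may report more compounds than this note shows. Statements on the series, on what has been measured and on what is new or still open speak of the compounds shown alone.

Compound 1, `O=C(NO)c1ccc(NCc2nc(-c3cccc(Cl)c3)nn2-c2ccccc2)cc1`, gives 61.2% in an assay on Sf9 cells for inhibition of protein deacetylase HDAC6 (Homo sapiens), read by fluorescence, with a stated time of 40 min, tested at 100 nM; a higher number here means more inhibition at the concentration tested (going by the name of the read-out), a lower number less inhibition.
Compound 2, `Cc1ccccc1-c1nc(CNc2ccc(C(=O)NO)cc2)n(-c2ccccc2)n1`, gives 53.2% in this assay.
Compound 3, `CC(C)c1ccc(-c2nc(CNc3ccc(C(=O)NO)cc3)n(-c3ccccc3)n2)cc1`, gives 27.6% in this assay.

Compound 3 stands lowest of the three in this assay, with compound 2 nearest and compound 1 furthest. Both steps that lead into it carry the 4-isopropylphenyl group: a number 33.6 percentage points lower from compound 1 to compound 3 (beyond the scatter) and a number 25.6 percentage points lower from compound 2 to compound 3 (beyond the scatter), each beyond the scatter, whereas a number 8 percentage points lower from compound 1 to compound 2 (within the scatter) stays within it.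

Compound 4, `O=C(NO)c1ccc(NCc2nc(-c3ccccn3)nn2-c2ccccc2)cc1`, differs from compound 3 in one place: pyridin-2-yl in place of 4-isopropylphenyl on an aromatic carbon. Within the data shown here, neither measured step involves a pyridin-2-yl group, so there is no direct precedent for the incoming group. What the measured steps do show is that both routes into compound 3 lowered the number once 4-isopropylphenyl was present, and compound 4 removes that group. Compound 4 is therefore expected to move back upward, by about a number 22.4 percentage points higher from compound 3 to compound 4 (beyond the scatter), toward the range of compound 1 and compound 2. The estimate for compound 4 in this assay is 50%, with a range from 25% to 75%.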

Compound 4, a percentage reported as inhibition, at one concentration (the size of the read-out at that concentration, not a potency): 58.6%
Beside the measured number, compound 4's estimate is 8.6 percentage points below it, within the range that was stated.
By their numbers in this assay, from the lowest: compound 3; then compounds 2, 4 and 1 (each within the scatter of the next).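

Replacing 4-isopropylphenyl with pyridin-2-yl gives a number 31 percentage points higher from compound 3 to compound 4 (beyond the scatter) in this assay, which shows that the aromatic group at this position can carry a ring nitrogen and its hydrogen-bond acceptor without the loss seen with 4-isopropylphenyl. The same change gives a number 5.4 percentage points higher from compound 2 to compound 4 (within the scatter) and a number 2.6 percentage points lower from compound 1 to compound 4 (within the scatter), so compounds 1, 2 and 4 cannot be told apart, and among these four compounds only 4-isopropylphenyl stands apart. Nothing available explains the difference between these groups at this position.

As far as these compounds go, it remains open whether a group with no aromatic ring, such as piperidine, or a phenyl ring carrying a carboxylic acid or an amine, would keep the number in this range. From the compounds shown here alone, these are percentages at one concentration, which give the size of the effect at that concentration only, so whether compounds 1, 2 and 4 would show a stronger or weaker effect than one another at other concentrations also remains open.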